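Nitro on the Phenyl: From Compound 3 to Compound 4

This account rests on a few compounds, and the source may have more. Where it says the series, first, only, none or still open, it means among the compounds named here.

Compound 3 `c1ccc(CSc2nnc(-c3ccncc3)n2-c2ccccc2)cc1` bears an unsubstituted phenyl on its side chain. In a functional assay on MCF7 cells (Homo sapiens) for inhibition, read by MTT assay, with a stated time of 48 h (on this read-out higher numbers stand for weaker inhibition and lower numbers for stronger inhibition), compound 3 gives 22400 nM. Compound 2 `Brc1ccccc1CSc1nnc(-c2ccncc2)n1-c1ccccc1` gives 16100 nM in this assay, and the two stand within the scatter of each other, since a 1.4-fold higher number from compound 2 to compound 3 (0.14 log units; within the scatter). For the measured compounds named here, the only other value recorded is a limit of the assay: compound 1 `Fc1ccccc1CSc1nnc(-c2ccncc2)n1-c1ccccc1` gives > 50000 nM in this assay (the limit of > 50000 nM in this assay, at which 1 of the 3 values shown sits). Compound 4 `O=[N+]([O-])c1cccc(CSc2nnc(-c3ccncc3)n2-c2ccccc2)c1` differs from compound 3 by nitro in place of hydrogen on an aromatic carbon. Going by the values given here, no measured step changes that position; the steps at hand, an at least 3.1-fold lower number from compound 1 to compound 2 (0.49 log units; beyond the scatter) and an at least 2.2-fold lower number from compound 1 to compound 3 (0.34 log units; beyond the scatter), show only that fluoro on the aromatic ring raised the number while bromo and hydrogen gave alike results. On that basis a nitro at a fresh position gives no ground to expect a shift beyond the scatter in this assay in either direction. For compound 4 the expected step is a 1.1-fold higher number from compound 3 to compound 4 (0.05 log units; within the scatter), a small one. Compound 4 is therefore estimated at 25000 nM, within a range from 8000 nM to 80000 nM.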

Compound 4, half-maximal inhibitory concentration: 18300 nM
Estimate against measurement, compound 4: 1.4-fold (0.14 log units) above, within the range that was stated.
By their numbers in this assay, from the lowest: compounds 2, 4 and 3 (each within the scatter of the next). At a limit, above all of these: compound 1.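

The first change made at this ring position gives no separation in this assay, although nitro adds three heavy atoms where there was only hydrogen (a 1.2-fold lower number from compound 3 to compound 4 (0.09 log units; within the scatter)). The 3-nitrophenyl side chain of compound 4 also stands within the scatter of the 2-bromophenyl side chain of compound 2 (a 1.1-fold higher number from compound 2 to compound 4 (0.06 log units; within the scatter)), so compounds 2, 3 and 4 form one group despite their different substituents and positions. Only compound 1, with its 2-fluorophenyl side chain, stands apart from compound 4 (an at least 2.7-fold lower number from compound 1 to compound 4 (0.43 log units; beyond the scatter)), and its value is a limit: the limit of > 50000 nM in this assay, at which 1 of the 4 values shown sits.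

Going by these compounds, whether an amine or a carboxylic acid at this same position would also stay within the scatter remains open. So does whether nitro at another position on this ring would give a similar number.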